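From a Bromomethyl Ketone to a Free Thiol

A few compounds are considered here, and "the series" means these few. Any claim that something is new, unique, unknown or untested is made for them only; others in the source may bear on it.

Of the compounds shown here, three built on one shared core have been measured in an ADME assay for pharmacokinetics, read by HPLC, in phosphate buffer, with a stated time of 72 h, at pH 7.4, tested at 250 uM; on this read-out higher numbers stand for a longer-lived compound and lower numbers for a shorter-lived compound. Compound 1 `C=CS(=O)(=O)c1cc(C(F)(F)F)cc(C(F)(F)F)c1` carries a vinylsulfonyl group on the ring; in this assay compound 1 gives < 0.017 h, which is a limit of the assay rather than a number. Compound 2 `C=Cc1cc(C(F)(F)F)cc(C(F)(F)F)c1` carries a plain vinyl group; compound 2 gives > 50 h, again only a limit. Compound 3 `O=C(CBr)c1cc(C(F)(F)F)cc(C(F)(F)F)c1` carries a (bromomethyl)carbonyl group; compound 3 gives < 0.017 h, also a limit. So compound 3 sits at the short-lived end of the range, at the limit of < 0.017 h in this assay, at which 2 of the 3 values shown sit, while compound 2 alone reaches (the limit of > 50 h in this assay, at which 1 of the 3 values shown sits). The measured steps are an at least 2900-fold higher number from compound 1 to compound 2 (3.46 log units; beyond the scatter) and an at least 2900-fold lower number from compound 2 to compound 3 (3.46 log units; beyond the scatter), whereas a step that the two limits leave unreadable from compound 1 to compound 3.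

Compound 4 `FC(F)(F)c1cc(S)cc(C(F)(F)F)c1` has not yet been measured. The change is sulfanyl in place of (bromomethyl)carbonyl on an aromatic carbon. The step that bears on it most is an at least 2900-fold lower number from compound 2 to compound 3 (3.46 log units; beyond the scatter), which shows that removing the (bromomethyl)carbonyl group from the core is tied to a very large change in half-life. No measured step introduces a sulfanyl group, so the size of its own effect is not shown. A large rise is therefore expected, an at least 1700-fold higher number from compound 3 to compound 4 (3.24 log units; beyond the scatter), with the possibility that the assay again reports only a limit. Compound 4 is estimated at 30 h, within a range from 3 h to 150 h.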

Compound 4, half-life: 31.5 h
Compound 4: middle estimate off by 1.1-fold (0.02 log units), on the low side; the range from low to high includes it.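

Among the compounds shown here, on the shared core, at the place meta to two trifluoromethyl groups, the sulfanyl group gives the only one of the four compounds whose half-life in this assay is a readable number rather than a limit. Sulfanyl in place of (bromomethyl)carbonyl goes with an at least 1800-fold higher number from compound 3 to compound 4 (3.26 log units; beyond the scatter), and sulfanyl in place of vinylsulfonyl goes with an at least 1800-fold higher number from compound 1 to compound 4 (3.26 log units; beyond the scatter), and both steps are floors, so the true gaps may be larger still. The comparison with the plain vinyl group reads differently, with an at least 1.5-fold lower number from compound 2 to compound 4 (0.20 log units; that floor lies within the scatter), a floor that does not separate the two compounds and that starts from a limit of compound 2: the limit of > 50 h in this assay, at which 1 of the 4 values shown sits.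

The real half-life of compound 2 stays hidden behind that limit, so the compounds shown do not tell how far compound 4 lies from it in either direction. They also leave open whether a long half-life belongs to the sulfanyl group alone or would also be seen with a hydroxyl group, an amine or a methylthio group at this same place on the core.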